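Swapping a methyl for a nitro on a known scaffold

The compounds below may be only part of what the source reports. "The series", "measured", "known", "first", "only" and "open" are said of these compounds alone.

Measured compounds:
compound 1, `Cc1nn(C)c2c1C(c1cccc(Cl)c1)=NCCN2`, 0.63 mg/kg
compound 2, `Cc1nn(C)c2c1C(c1cccc(Br)c1)=NCCN2`, 0.63 mg/kg
compound 3, `Cc1cccc(C2=NCCNc3c2c(C)nn3C)c1`, 2.5 mg/kg

All three share one core and differ only in the group carried on the attached benzene ring. In a functional assay on the whole organism for positive allosteric modulation, with Rattus norvegicus as the target (a higher number here means that more compound is needed for the effect, a lower number that less compound is needed), compound 3 gives the highest number of the three; the step of a 4.0-fold higher number from compound 1 to compound 3 (0.60 log units; beyond the scatter) and the step of a 4.0-fold higher number from compound 2 to compound 3 (0.60 log units; beyond the scatter) both lie beyond the scatter, whereas no change at the digits printed from compound 1 to compound 2 (within the scatter) shows that the two halogens cannot be told apart.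

Compound 4, `Cc1nn(C)c2c1C(c1cccc([N+](=O)[O-])c1)=NCCN2`, has not yet been tested. The change from compound 3 is nitro in place of methyl on an aromatic carbon. Among the compounds with values here, no measured step introduces a nitro group, so the only guidance is indirect: replacing the methyl by either halogen lowered the number by a modest amount, which suggests that the methyl is not the best group at this position. Nitro is a different kind of substituent, so an improvement of similar size is plausible but uncertain. Compound 4 is therefore expected to show a modest drop, a 2.0-fold lower number from compound 3 to compound 4 (0.30 log units; within the scatter), giving an estimated 1.25 mg/kg with a range from 0.3 mg/kg to 5 mg/kg in this assay.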

Compound 4, minimum effective dose: 5 mg/kg
Compound 4: the middle estimate sits 4.0-fold (0.60 log units) below what was measured; low and high end bracket the measured number.
By their numbers in this assay, from the lowest: compounds 1 and 2 (each within the scatter of the next); then compounds 3 and 4 (each within the scatter of the next).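

In this assay, within the data shown here, nitro is the first group at this place on the benzene ring to bring in nitrogen, oxygen and hydrogen-bond acceptors, yet a 2.0-fold higher number from compound 3 to compound 4 (0.30 log units; within the scatter) means that it cannot be told apart from methyl. The two halogens remain clearly separated from nitro, with a 7.9-fold higher number from compound 1 to compound 4 (0.90 log units; beyond the scatter) and a 7.9-fold higher number from compound 2 to compound 4 (0.90 log units; beyond the scatter) in this assay. The four compounds therefore fall into two groups, chloro and bromo on one side and methyl and nitro on the other, and nothing available explains this split.

Still open, from the compounds shown here alone, is whether any other group at this place can match or pass chloro and bromo: fluoro, methoxy, an amine or a carboxylic acid would each test this. Also open, going by these compounds, is whether these groups would keep the same order on another carbon of the benzene ring.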